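The source may hold more compounds than are shown below. What is called first, only, known or untested is meant among the compounds shown, and "the series" means these compounds.

Compound 1 `COc1ccc(C(=O)c2sc(Nc3ccccc3)nc2N)cc1OC`: 6900 nM
Compound 2 `COc1ccc(Nc2nc(N)c(C(=O)c3ccc(OC)c(OC)c3)s2)cc1`: 10 nM
Compound 3 `Nc1nc(Nc2ccc(F)cc2)sc1C(=O)c1ccccc1`: > 10000 nM

Of the compounds shown here, three that share a core have been tested in a functional assay on CCRF-CEM cells (Homo sapiens) for antiproliferative activity, read by cell counting, with a stated time of 2 days; a higher number here means a weaker inhibitor, a lower number a stronger inhibitor. Compound 1 gives 6900 nM in this assay, and compound 2 gives 10 nM. The two differ in one place, (methoxy in place of hydrogen on an aromatic carbon), and that single change brings a 690-fold lower number from compound 1 to compound 2 (2.84 log units; beyond the scatter). For compound 3 the result is only a limit, > 10000 nM, so its true value is not known; this is the limit described by the limit of > 10000 nM in this assay, at which 1 of the 3 values shown sits.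

Compound 4 `COc1ccc(C(=O)c2sc(Nc3ccc(F)cc3)nc2N)cc1` has not yet been measured. It differs from compound 3 by methoxy in place of hydrogen on an aromatic carbon. Among the measured compounds shown here, this is the same kind of change as the one from compound 1 to compound 2: the place is described in the same words, yet the wider reading differs, since for compound 1 to compound 2 it also reads anilino to (4-methoxyphenyl)amino, while for compound 3 to compound 4 it reads only phenyl to 4-methoxyphenyl. How the core of compound 3 differs from the core of compound 1 is not broken down here.

Because compound 3 sits at a limit, the step to compound 4 cannot be pinned down; an improvement of an at least 3.3-fold lower number from compound 3 to compound 4 (0.52 log units; beyond the scatter) is expected, smaller than the earlier step, since the methoxy here enters a different ring. Compound 4 is expected to give about 3000 nM, likely between 500 nM and 10000 nM.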

Compound 4, half-maximal inhibitory concentration: > 10000 nM
Compound 4 was reported as a limit; the forecaster's own chance of this, stated with the estimate: 35%; middle value at least 3.3-fold (0.52 log units) from the limit.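

In this assay compound 4 gives > 10000 nM, which is a limit of the assay and not a number. Compound 3 stands at the same limit, so no step can be read between compound 3 and compound 4: the limit of > 10000 nM in this assay, at which 2 of the 4 values shown sit.

As far as these compounds go, what stays open is where the true values of compound 3 and compound 4 lie, and whether methoxy in place of hydrogen on this ring changes the result at all.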